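Removing a Methyl from a Ring Oxygen on a Second Core

A few compounds are considered here, and "the series" means these few. Any claim that something is new, unique, unknown or untested is made for them only; others in the source may bear on it.

Compound 1 `COc1ccc(/C=C2\CCC/C(=C\c3cccc(OC)c3OC)C2=O)cc1OC` and compound 2 `COc1cc(/C=C2\CCC/C(=C\c3cccc(OC)c3OC)C2=O)ccc1O` differ in one place only: hydrogen in place of methyl on an oxygen on an aromatic ring. In a functional assay on SW-620 cells (Homo sapiens) for cytotoxicity, read by MTT assay, with a stated time of 72 h (a lower number here means a stronger inhibitor, a higher number a weaker inhibitor), compound 1 gives 6400 nM, and compound 2 gives 8600 nM, so that a 1.3-fold higher number from compound 1 to compound 2 (0.13 log units; within the scatter). Compound 3 `COc1cc(/C=C2\CCC/C(=C\c3ccc(OC)c(OC)c3)C2=O)ccc1O` gives 4500 nM in this assay; the difference between its core and that of compound 1 is not broken down here. Compound 4 `COc1ccc(/C=C2\CCC/C(=C\c3ccc(O)c(O)c3)C2=O)cc1OC` has not been measured; it carries the same change as compound 2, here (hydrogen in place of methyl on an oxygen on an aromatic ring), with the place described in the same words. Because a 1.3-fold higher number from compound 1 to compound 2 (0.13 log units; within the scatter) stayed within the scatter, a step of similar size is expected in this assay, namely a 1.3-fold higher number from compound 3 to compound 4 (0.12 log units; within the scatter). Compound 4 is therefore estimated at 6000 nM, most likely between 3000 nM and 12000 nM.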

Compound 4, half-maximal inhibitory concentration: 10500 nM
The estimate for compound 4 lay 1.8-fold (0.24 log units) below the measured number; the range from low to high includes it.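

Hydrogen in place of methyl on an oxygen on an aromatic ring gives in this assay a 2.3-fold higher number from compound 3 to compound 4 (0.37 log units; beyond the scatter) and so a modest step, whereas the earlier step stayed within the scatter. Even so, the two steps cannot be told apart: the same change on two cores in this assay, a 1.3-fold higher number (0.13 log units; within the scatter) from compound 1 to compound 2 and a 2.3-fold higher number (0.37 log units; beyond the scatter) from compound 3 to compound 4, 1.7-fold (0.24 log units) apart, within the scatter of two such steps. The change therefore carries from the core of compound 1 to the core of compound 3 without a measurable difference, but two cores do not show that the steps are equal or that the same would hold on any other core.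

The compounds shown leave open how an ethyl group on the same oxygen or a longer chain there would compare. They also leave open what an amine in place of the hydroxy group would do.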